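Methyl added to a triazolo core with no measurable inhibition

A few compounds are considered here, and "the series" means these few. Any claim that something is new, unique, unknown or untested is made for them only; others in the source may bear on it.

Measured so far:
- compound 1 `Cc1nnc(S)n2c(C)nc(C)c12`: > 48000 nM in a functional assay for inhibition, with Homo sapiens as the target; on this read-out higher numbers stand for weaker inhibition and lower numbers for stronger inhibition
- compound 2 `CCCc1ncc2cnnc(S)n12`: > 48000 nM in this assay
- compound 3 `CCCc1ncc2c(C)nnc(S)n12`: > 48000 nM in this assay

Each of these values is a limit of the assay rather than a number. Compound 3 gives only such a limit, and the other two values shown are limits as well, so compound 3 cannot be placed above or below either of them; all three sit together at the limit of > 48000 nM in this assay, at which 3 of the 3 values shown sit.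

Compound 4 `CCCc1nc(C)c2c(C)nnc(S)n12` differs from compound 3 by methyl in place of hydrogen on an aromatic carbon.

Among the compounds with values here, the one measured step of the same kind, a step that the two limits leave unreadable from compound 2 to compound 3, is not readable because both ends are limits. Within the data shown here, no measured step therefore gives a size or a direction for the change to compound 4 in this assay; the data only show that the same kind of change left the value at a limit before.

On that basis compound 4 is expected to give 70000 nM, within 30000 nM to 200000 nM, which means an expected step that the limit leaves unreadable from compound 3 to compound 4; most likely the assay will again report only a limit.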

Compound 4, half-maximal inhibitory concentration: 45000 nM
Compound 4: middle estimate off by 1.6-fold (0.19 log units), on the high side; the range from low to high includes it.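

With methyl in place of hydrogen on this aromatic carbon, the series gives its first actual number in this assay, while every other compound shown stays at a limit: the limit of > 48000 nM in this assay, at which 3 of the 4 values shown sit.

The methyl change amounts to an at least 1.0-fold lower number from compound 3 to compound 4 (0.02 log units; that floor lies within the scatter), and ethyl in place of hydrogen on a saturated chain carbon bound to an aromatic carbon amounts to an at least 1.0-fold lower number from compound 1 to compound 4 (0.02 log units; that floor lies within the scatter). Both are only floors that lie within the scatter, so neither change is shown to strengthen inhibition, and the steps whose two ends are both limits cannot be read.

As far as these compounds go, the true size of the methyl step stays open, as compound 3 carries only a limit. Also open, from the compounds shown here alone, is whether a longer chain or an amine on this aromatic carbon would give a lower number than compound 4.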